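The source may hold more compounds than are shown below. What is called first, only, known or untested is meant among the compounds shown, and "the series" means these compounds.

Measured in a functional assay on HL-60 cells (Homo sapiens) for antiproliferative activity, with a stated time of 72 h; on this read-out lower numbers stand for stronger inhibition and higher numbers for weaker inhibition:
- compound 1 `OC[C@H]1O[C@@H](n2cnc3c(NCc4ccccc4Br)ncnc32)[C@H](O)[C@@H]1O`: 6600 nM
- compound 2 `OC[C@H]1O[C@@H](n2cnc3c(NCc4c(F)ccc(F)c4F)ncnc32)[C@H](O)[C@@H]1O`: 13000 nM

Compound 2, at 13000 nM, stands level with compound 1 within the scatter. Compound 3 `Cc1ccc(O)c(CNc2ncnc3c2ncn3[C@@H]2O[C@H](CO)[C@@H](O)[C@H]2O)c1` differs from compound 2 in one group: 2-hydroxy-5-methylphenyl in place of 2,3,6-trifluorophenyl on a saturated chain carbon bound to a nitrogen on an aromatic ring. Among the measured compounds shown here, the only measured step at this place is a 2.0-fold higher number from compound 1 to compound 2 (0.29 log units; within the scatter). That single exchange of one substituted phenyl for another gives no ground to expect a step beyond the scatter in this assay, in either direction. The estimated step is a 1.3-fold lower number from compound 2 to compound 3 (0.11 log units; within the scatter). For compound 3 the expected value is 10000 nM, with an estimated range of 3500 nM to 28000 nM.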

Compound 3, half-maximal inhibitory concentration: 15000 nM
Beside the measured number, compound 3's estimate is 1.5-fold (0.18 log units) below it, and the stated range covers the measured number.
By their numbers in this assay, from the lowest: compounds 1, 2 and 3 (each within the scatter of the next, the first and the last beyond it).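

In this assay, 2-hydroxy-5-methylphenyl in place of 2,3,6-trifluorophenyl on this saturated chain carbon gives a 1.2-fold higher number from compound 2 to compound 3 (0.06 log units; within the scatter), so this exchange leaves the number level within the scatter. Among the compounds shown here, the same group in place of 2-bromophenyl gives a 2.3-fold higher number from compound 1 to compound 3 (0.36 log units; beyond the scatter), the first step at this place to pass the scatter, though only modestly. No measurement shown bears on the reason for either step. On these data alone, all three compounds carry a substituted phenyl here, so what a cyclohexyl ring or a longer alkyl chain at this carbon would do remains open.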